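This account rests on a few compounds, and the source may have more. Where it says the series, first, only, none or still open, it means among the compounds named here.

Measured in an ADME assay on microsomes from liver (Homo sapiens) for metabolic stability, read by LC-MS, with a stated time of 4 h, tested at 1 uM; a lower number here means slower removal, a higher number faster removal of the compound:
- Compound 1 `Cc1cc(CNC(=O)Nc2cc(Cl)nc(OCC(F)F)c2)nnc1-c1cn(C)nc1C(F)(F)F`: < 50 mL/min/kg, a limit
- Compound 2 `CCOc1cc(NC(=O)NCc2cc(C)c(-c3cn(C)nc3C(F)(F)F)nn2)cc(C#N)n1`: < 28.4 mL/min/kg, a limit

Compound 1 stands only at its limit of < 50 mL/min/kg, and no number is available for it. Compound 2 is also known only through a limit, < 28.4 mL/min/kg. Among the measured compounds shown here, the series therefore offers no measured step between compounds.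

Compound 3 `COCCOc1cc(NC(=O)NCc2cc(C)c(-c3cn(C)nc3C(F)(F)F)nn2)cc(Cl)n1` keeps the core of compound 1 and carries methoxymethyl in place of difluoromethyl on a saturated chain carbon bound to an oxygen on an aromatic ring, which reads as 2-methoxyethoxy for 2,2-difluoroethoxy (methoxymethyl in place of difluoromethyl on a saturated chain carbon bound to an oxygen on an aromatic ring).

For the measured compounds named here, with no measured step as a guide, the expected step that the limit leaves unreadable from compound 1 to compound 3 stays within the usual scatter of this assay, with no direction expected. For compound 3 the estimated clearance is 28 mL/min/kg, with an expected range of 14 mL/min/kg to 55 mL/min/kg.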

Compound 3, clearance: < 23.4 mL/min/kg
Compound 3: only a limit was reported (the forecaster's own chance of this, stated with the estimate: 65%); at least 1.1-fold (0.07 log units) between middle value and limit.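

In this assay compound 3 gives < 23.4 mL/min/kg as a limit. Among the compounds shown here, compound 1 gives < 50 mL/min/kg as a limit too, and no step from compound 1 to compound 3 can be read. Going by these compounds, whether 2-methoxyethoxy in place of 2,2-difluoroethoxy changes clearance at all stays open.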